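Cyclopropylamino to anilino on the shared core

A few compounds are considered here, and "the series" means these few. Any claim that something is new, unique, unknown or untested is made for them only; others in the source may bear on it.

Three compounds of the series have numbers in a functional assay on A549 cells (Homo sapiens) for inhibition, with a stated time of 72 h; on this read-out higher numbers stand for weaker inhibition and lower numbers for stronger inhibition. Compound 1 `Cc1cc(Cl)ccc1NC(=O)Nc1nc(NC2CC2)cc(Sc2c[nH]c3ccccc23)n1` gives 31500 nM in this assay, the highest of the two numbers shown. Compound 2 `COc1ccc(NC(=O)Nc2nc(Sc3c[nH]c4ccccc34)cc(N3CCCCC3)n2)cc1` gives 13500 nM, a gap from compound 1 that is beyond the scatter. Compound 3 `COc1cc(NC(=O)Nc2nc(Nc3cc(OC)cc(OC)c3)cc(Sc3c[nH]c4ccccc34)n2)cc(OC)c1` returns only a limit of the assay, > 50000 nM, and no number. That limit is noted as the limit of > 50000 nM in this assay, at which 1 of the 3 values shown sits.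

Compound 4 `Cc1cc(Cl)ccc1NC(=O)Nc1nc(Nc2ccccc2)cc(Sc2c[nH]c3ccccc23)n1` is not yet measured. It differs from compound 1 in one place: phenyl in place of cyclopropyl on a nitrogen on an aromatic ring. Within the data shown here, no measured pair in the set covers this same change, so no step size can be read off. Compound 3 carries a substituted anilino group on the same nitrogen and sits at the limit, which weighs against expecting a sharp improvement, while compound 2 shows that a change at this position can move the number in either direction.

The working expectation is a step of a 1.0-fold higher number from compound 1 to compound 4 (0.01 log units; within the scatter), within the scatter or at most slightly weaker, for compound 4. Compound 4 is estimated at 32000 nM in this assay, with a range from 11000 nM to 90000 nM.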

Compound 4, half-maximal inhibitory concentration: > 50000 nM
Compound 4 ended at the assay's limit; the forecaster's own chance of this, stated with the estimate: 30%; middle value at least 1.5-fold (0.19 log units) away from the limit.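

In this assay, among these compounds, the change from cyclopropylamino to anilino gives the first step that can be read at this position, an at least 1.5-fold higher number from compound 1 to compound 4 (0.20 log units; that floor lies within the scatter), and it is only a floor. Compound 4 gives > 50000 nM, which is a limit of the assay and not a number. Phenyl in place of cyclopropyl on this nitrogen, with the rest of compound 1 held the same, therefore gives no number under that limit, and the limit now recurs in the series shown: the limit of > 50000 nM in this assay, at which 2 of the 4 values shown sit.

The true size of the step cannot be read, and its floor alone does not separate compound 4 from compound 1 beyond the scatter, so a real loss on going from cyclopropyl to phenyl remains unproven. Also open, from the compounds shown here alone, is whether a smaller or more open group on this same nitrogen, such as methyl, a hydroxyethyl chain or a longer chain ending in a dimethylamine, would give a lower number than compound 1 or also end at the limit.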